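The source may report more compounds than this note shows. Statements on the series, on what has been measured and on what is new or still open speak of the compounds shown alone.

Working notes on the series, measured so far:

- compound 1 `CC(C)C(c1ccc(-c2ccc3cccc(F)c3c2)[nH]c1=O)C1SC(=O)NC1=O`: 0.76 h
- compound 2 `O=C1NC(=O)/C(=C/C(c2ccc(-c3ccc4cccc(F)c4c3)[nH]c2=O)C2CCCCC2)O1`: 2.39 h
- compound 3 `CC(C)C(/C=C1\OC(=O)NC1=O)c1cc(Cl)c(-c2ccc3cccc(F)c3c2)[nH]c1=O`: > 3 h

All three values come from an ADME assay on microsomes from liver (Rattus norvegicus) for metabolic stability; on this read-out lower numbers stand for a shorter-lived compound and higher numbers for a longer-lived compound. In this assay compound 1 gives 0.76 h, the lower of the two actual numbers. Compound 2 gives 2.39 h, and this gap to compound 1 lies beyond the scatter. Compound 3 reads > 3 h, which is a limit of the assay and not a number.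

The next compound to be read is compound 4 `CC(C)C(c1ccc(-c2ccc3cccc(F)c3c2)[nH]c1=O)C1C(=O)NC(=O)N1C`, which differs from compound 1 in one place: 3-methyl-2,5-dioxoimidazolidin-4-yl in place of 2,4-dioxo-1,3-thiazolidin-5-yl on a saturated chain carbon bound to an aromatic carbon and a saturated chain carbon. The core of compound 1 stays as it is.

Within the data shown here, no measured pair isolates this change, so the expected size of the step in this assay rests on little. Compound 1 sits at the short-lived end at 0.76 h, and neither of the other two compounds reads lower. A modest step towards a longer half-life is therefore expected, one that may not clear the scatter. The expected change is a 1.7-fold higher number from compound 1 to compound 4 (0.23 log units; within the scatter). For compound 4 the estimated half-life is 1.3 h, with an expected range from 0.5 h to 3 h.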

Compound 4, half-life: 0.263 h
The estimate for compound 4 lay 4.9-fold (0.69 log units) above the measured number; the measured number lies below the stated range.
By their numbers in this assay, from the lowest: compound 4; then compound 1; then compound 2. At a limit, above all of these: compound 3.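

Among these compounds, exchanging 2,4-dioxo-1,3-thiazolidin-5-yl for 3-methyl-2,5-dioxoimidazolidin-4-yl on this saturated chain carbon gives, in this assay, a 2.9-fold lower number from compound 1 to compound 4 (0.46 log units; beyond the scatter) and thereby supplies the first pair that differs in one place. With the core of compound 1 unchanged, it shows that this position alone can move the half-life beyond the scatter, and that here the move with 3-methyl-2,5-dioxoimidazolidin-4-yl runs towards the short-lived end. Nothing measured in the series accounts for the size or direction of this step.

As far as these compounds go, it remains open how much of the step belongs to the ring exchange and how much to the methyl group, a question that a 2,5-dioxoimidazolidin-4-yl group without the methyl would address. Also open, from the compounds shown here alone, is where a carboxylic acid or a primary amide at this place would fall relative to compound 1 in this assay on the same core.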